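The source may hold more compounds than are shown below. What is called first, only, known or untested is meant among the compounds shown, and "the series" means these compounds.

Compound 2 `CCOC(=O)c1ccc(NC(=O)N[C@@H](C)c2ccccc2)cc1` gives 92% in an ADME assay on the whole organism with Oryza sativa as the target, tested at 10 uM (on this read-out higher numbers stand for a weaker effect at the one concentration tested and lower numbers for a stronger effect), and compound 1 `CC(C)c1ccc(NC(=O)N[C@@H](C)c2ccccc2)cc1` gives 86%, so the two numbers sit within the scatter of each other, as the step of a number 6 percentage points higher from compound 1 to compound 2 (within the scatter) shows. Compound 3 `C[C@H](NC(=O)Nc1ccc(F)cc1)c1ccccc1` differs from compound 2 by fluoro in place of ethoxycarbonyl on an aromatic carbon. For the measured compounds named here, no measured step swaps these two groups, and the one step known, swapping groups on an aromatic carbon, stayed within the scatter. An expected step of a number 2 percentage points lower from compound 2 to compound 3 (within the scatter) therefore means no change beyond the scatter. Compound 3 is estimated at 90%, between 78% and 99%.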

Compound 3, a percentage reported as activity, at one concentration (the size of the read-out at that concentration, not a potency): 85%
The estimate for compound 3 lay 5 percentage points above the measured number; the measured number falls inside the stated range.
By their numbers in this assay, from the lowest: compounds 3, 1 and 2 (each within the scatter of the next).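

In this assay, fluoro can replace ethoxycarbonyl on this aromatic carbon, para to a large group, with a number 7 percentage points lower from compound 2 to compound 3 (within the scatter) as the result. Replacing isopropyl with fluoro gives a number 1 percentage points lower from compound 1 to compound 3 (within the scatter) as well, so all three groups now read alike at this position, even though fluoro is far smaller than ethoxycarbonyl by heavy-atom count and has no hydrogen-bond acceptors. No measurement is available to explain this flat picture. As far as these compounds go, whether an amine, a carboxylic acid or a longer chain here would move the number beyond the scatter stays open, as does the effect of changes elsewhere on the shared core.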